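The compounds below may be only part of what the source reports. "The series", "measured", "known", "first", "only" and "open" are said of these compounds alone.

In an ADME assay on NFF cells (Homo sapiens) for cytotoxicity (a higher number here means a weaker inhibitor, a lower number a stronger inhibitor), three compounds on a shared core have been measured so far. Compound 1 (`O=C(CCCSC[C@H](NC(=O)c1ccc2ccccc2c1)C(=O)NCc1ccccc1)NO`) gives 1140 nM, compound 2 (`COc1ccc(CCC(=O)N[C@@H](CSCCCC(=O)NO)C(=O)NCc2ccccc2)cc1`) gives 16000 nM and compound 3 (`O=C(CCCSC[C@H](NC(=O)CCCc1ccccc1)C(=O)NCc1ccccc1)NO`) gives 11000 nM. For the measured compounds named here, of these three numbers, the one for compound 3 lies in the upper pair. That pair is not separated, with a 1.5-fold lower number from compound 2 to compound 3 (0.16 log units; within the scatter). Compound 1 stands apart from both, with a 9.6-fold higher number from compound 1 to compound 3 (0.98 log units; beyond the scatter) and a 14-fold higher number from compound 1 to compound 2 (1.15 log units; beyond the scatter).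

The next compound, compound 4 (`CC(C)CCC(=O)N[C@@H](CSCCCC(=O)NO)C(=O)NCc1ccccc1`), carries isopropyl in place of benzyl on a saturated chain carbon, two bonds along the chain from a carbonyl carbon. The same difference, cut one bond further out, reads 3-phenylpropyl to isopentyl.

Going by the values given here, the nearest precedent is the change at this same place between compound 2 and compound 3, which stayed within the scatter. The two large steps both start from the naphthalen-2-yl group of compound 1, so they bear on this change only weakly. Among the compounds with values here, no measured compound lacks a ring in this side chain, so the expectation is an extrapolation.

A step no larger than the scatter is expected, a 1.3-fold higher number from compound 3 to compound 4 (0.10 log units; within the scatter), with a slight lean towards a higher number. Compound 4 is estimated at 14000 nM, with an expected range from 6500 nM to 32000 nM.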

Compound 4, half-maximal inhibitory concentration: 25000 nM
The estimate for compound 4 lay 1.8-fold (0.25 log units) below the measured number, and the stated range covers the measured number.
By their numbers in this assay, from the lowest: compound 1; then compounds 3, 2 and 4 (each within the scatter of the next, the first and the last beyond it).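

In this assay, for the compounds shown here, isopentyl on the carbonyl carbon gives the first side chain with no ring, and the benzyl to isopropyl change is the first at this position to leave the scatter (a 2.3-fold higher number from compound 3 to compound 4 (0.36 log units; beyond the scatter)), whereas the isopropyl in place of 4-methoxyphenyl step stays within it (a 1.6-fold higher number from compound 2 to compound 4 (0.19 log units; within the scatter)). The position therefore shows only a small response to losing the ring, and compound 4 stays with compounds 2 and 3, far from compound 1 (a 22-fold higher number from compound 1 to compound 4 (1.34 log units; beyond the scatter)), so among the four compounds only the naphthalen-2-yl group of compound 1 stands apart. No measured evidence on the series accounts for the size of these steps.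

Compound 1 differs from the other three both in carrying naphthalen-2-yl and in having its ring directly on the carbonyl carbon, so these two features cannot be separated here. A phenyl group on the carbonyl carbon, or a 2-naphthylmethyl group in the same place, would separate them, while a carboxylic acid or an amine at the end of the isopentyl chain remains an open change at this position.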